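The source may report more compounds than this note shows. Statements on the series, on what has been measured and on what is new or still open speak of the compounds shown alone.

Compound 1 `O=CCN1N=C(c2ccc3ccccc3c2)CC1c1cccc([N+](=O)[O-])c1`: 2980 nM in a functional assay on PC-3 cells (Homo sapiens) for cytotoxicity, read by sulforhodamine B assay, with a stated time of 48 h; a higher number here means a weaker inhibitor, a lower number a stronger inhibitor
Compound 2 `O=CCN1N=C(c2ccc3ccccc3c2)CC1c1cccc(Cl)c1Cl`: 17900 nM
Compound 3 `COc1ccc(C2CC(c3ccc4ccccc4c3)=NN2CC=O)cc1`: 4530 nM

Among these three numbers compound 3 stands second highest. Its nearest neighbour is compound 1, reached by a 1.5-fold higher number from compound 1 to compound 3 (0.18 log units; within the scatter), a step within the scatter, while compound 2 lies furthest away, by a 4.0-fold lower number from compound 2 to compound 3 (0.60 log units; beyond the scatter), a step beyond the scatter.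

Compound 4 `O=CCN1N=C(c2ccc3ccccc3c2)CC1/C=C/c1ccccc1` differs from compound 3 in one place: 2-phenylethenyl in place of 4-methoxyphenyl on a saturated ring carbon. Within the data shown here, no measured step exchanges an aryl group for a phenylethenyl group, so the only guidance comes from the three aryl exchanges at the same saturated ring carbon. These gave a 6.0-fold higher number from compound 1 to compound 2 (0.78 log units; beyond the scatter) and a 4.0-fold lower number from compound 2 to compound 3 (0.60 log units; beyond the scatter), both modest, and a 1.5-fold higher number from compound 1 to compound 3 (0.18 log units; within the scatter), which stayed within the scatter. Exchanges at this carbon have thus moved this assay only modestly in either direction, and the new group has no measured precedent. For compound 4 a step of about a 1.0-fold lower number from compound 3 to compound 4 (0.00 log units; within the scatter) is therefore expected, not clearly beyond the scatter, with a wide range allowed. Compound 4 is estimated at 4500 nM, between 1800 nM and 12000 nM.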

Compound 4, half-maximal inhibitory concentration: 19100 nM
Beside the measured number, compound 4's estimate is 4.2-fold (0.63 log units) below it; the whole stated range lies below it.
By their numbers in this assay, from the lowest: compounds 1 and 3 (each within the scatter of the next); then compounds 2 and 4 (each within the scatter of the next).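

In this assay the 2-phenylethenyl group is no neutral replacement for these aryl groups: a 4.2-fold higher number from compound 3 to compound 4 (0.62 log units; beyond the scatter) and a 6.4-fold higher number from compound 1 to compound 4 (0.81 log units; beyond the scatter) are both beyond the scatter, even though 4-methoxyphenyl and 2-phenylethenyl carry the same number of heavy atoms. Set against the 2,3-dichlorophenyl group, however, the change gives a 1.1-fold higher number from compound 2 to compound 4 (0.03 log units; within the scatter) and so stays within the scatter, which means that the four groups at this saturated ring carbon fall into two sets, compounds 1 and 3 with the lower numbers and compounds 2 and 4 with the higher. Nothing available bears on why this exchange behaves as it does. The compounds shown leave open whether the double bond of the 2-phenylethenyl group matters, which a saturated 2-phenylethyl chain at this carbon would test. They also leave open where an aminophenyl or a pyridyl group here would fall.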